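The source may report more compounds than this note shows. Statements on the series, on what has been measured and on what is new or still open speak of the compounds shown alone.

Measured so far in an ADME assay on cells (Homo sapiens) for activation; on this read-out higher numbers stand for lower toxicity in this test and lower numbers for higher toxicity in this test:
compound 1 `CCC1(S(=O)(=O)NC(=O)[C@@]23C[C@H]2/C=C\CCCCN(C)C(=O)N[C@@H](CCOc2cc(-c4nc(C(C)C)cs4)nc4c(Cl)c(OC)ccc24)C(=O)N3)CC1` gives 49300 nM
compound 2 `COc1ccc2c(OCC[C@@H]3NC(=O)N(C)CCCC/C=C\[C@@H]4C[C@@]4(C(=O)NS(=O)(=O)C4(C)CC4)NC3=O)cc(-c3nc(C(C)C)cs3)nc2c1Cl` gives 37400 nM
compound 3 `CCCn1cc(-c2cc(OCC[C@@H]3NC(=O)N(C)CCCC/C=C\[C@@H]4C[C@@]4(C(=O)NS(=O)(=O)C4(C)CC4)NC3=O)c3ccc(OC)c(C)c3n2)cn1` gives 62300 nM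

Compound 4 `CCn1cc(-c2cc(OCC[C@@H]3NC(=O)N(C)CCCC/C=C\[C@@H]4C[C@@]4(C(=O)NS(=O)(=O)C4(C)CC4)NC3=O)c3ccc(OC)c(C)c3n2)cn1` is not yet measured. The difference between the core of compound 1 and the core of compound 3 is not broken down here. The three measured numbers lie within the scatter of one another, so no order among them is claimed.

From compound 1 to compound 2 the change is hydrogen in place of methyl on a saturated chain carbon bound to a saturated ring carbon; the step in this assay is a 1.3-fold lower number from compound 1 to compound 2 (0.12 log units; within the scatter). From compound 3 to compound 4 the change is hydrogen in place of methyl on a saturated chain carbon, two bonds along the chain from an aromatic nitrogen. The two places are not the same: in compound 1 the carbon is bound to a saturated ring carbon, in compound 3 it sits two bonds along the chain from an aromatic nitrogen, so this is the same kind of change, not the same change.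

Because a 1.3-fold lower number from compound 1 to compound 2 (0.12 log units; within the scatter) stayed within the scatter, the expected step here is a 1.1-fold lower number from compound 3 to compound 4 (0.05 log units; within the scatter), also within the scatter. Compound 4 is therefore estimated at 55000 nM in this assay. The expected range for compound 4 runs from 30000 nM to 100000 nM.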

Compound 4, half-maximal cytotoxic concentration: 36700 nM
Beside the measured number, compound 4's estimate is 1.5-fold (0.18 log units) above it; measured number inside the range.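

In this assay the change from propyl to ethyl in the 1-propyl-1H-pyrazol-4-yl group gives a 1.7-fold lower number from compound 3 to compound 4 (0.23 log units; within the scatter) and so stays inside the usual scatter. This does not fix a size for the change or show that it is without effect on other cores, and the two places differ: one is a saturated chain carbon bound to a saturated ring carbon, the other a saturated chain carbon two bonds along the chain from an aromatic nitrogen, so these are two cases of the same kind of change. Across these two pairs only, hydrogen in place of methyl carries from one core to the other without a detectable difference between the steps: the same change on two cores in this assay, a 1.3-fold lower number (0.12 log units; within the scatter) from compound 1 to compound 2 and a 1.7-fold lower number (0.23 log units; within the scatter) from compound 3 to compound 4, 1.3-fold (0.11 log units) apart, within the scatter of two such steps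

The compounds shown leave open whether a longer chain than propyl, or an amine or a carboxylic acid carried on that chain, would also stay within the scatter. Also open, on these data alone, is how any read-out other than this assay responds to the change.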